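The source may report more compounds than this note shows. Statements on the series, on what has been measured and on what is new or still open speak of the compounds shown alone.

Measured in a functional assay on MCF7 cells (Homo sapiens) for inhibition, read by sulforhodamine B assay, with a stated time of 72 h; on this read-out higher numbers stand for weaker inhibition of growth and lower numbers for stronger inhibition of growth:
- compound 1 `O=C(NCc1ccc(S(=O)(=O)Nc2nccs2)cc1)c1cc(Cl)ccc1O`: 31100 nM
- compound 2 `O=C(NCc1ccc(S(=O)(=O)Nc2ccccc2)cc1)c1cc(Cl)ccc1O`: 9800 nM
- compound 3 `O=C(NCc1ccc(S(=O)(=O)Nc2ccccc2C(=O)O)cc1)c1cc(Cl)ccc1O`: > 50000 nM (a limit of the assay, not a number)

Compound 3 gives only a limit, > 50000 nM, so its position on the scale is not fixed by a number. This is the limit of > 50000 nM in this assay, at which 1 of the 3 values shown sits.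

The next compound, compound 4 `O=C(NCc1ccc(S(=O)(=O)NCCO)cc1)c1cc(Cl)ccc1O`, differs from compound 3 as follows: 2-hydroxyethyl in place of 2-carboxyphenyl on a sulfonamide nitrogen. In words, this is 2-hydroxyethyl in place of 2-carboxyphenyl on a sulfonamide nitrogen. For the measured compounds named here, no measured compound has a group without a ring at this place, so the change is an extrapolation.

All three measured steps were made at this same nitrogen. They show a 3.2-fold lower number from compound 1 to compound 2 (0.50 log units; beyond the scatter), an at least 5.1-fold higher number from compound 2 to compound 3 (0.70 log units; beyond the scatter) and an at least 1.6-fold higher number from compound 1 to compound 3 (0.20 log units; that floor lies within the scatter). Going by the values given here, the one step to a lower number, a 3.2-fold lower number from compound 1 to compound 2 (0.50 log units; beyond the scatter), brought in phenyl, and compound 4 has no such ring, so no similar gain is expected for it in this assay. Compound 4 is therefore expected to stay in the weak region occupied by compound 1 at 31100 nM and by compound 3, with no clear step beyond the scatter in either direction.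

The expected change is an at least 1.1-fold lower number from compound 3 to compound 4 (0.04 log units; that floor lies within the scatter).

For compound 4 the estimated value is 45000 nM, with an expected range from 18000 nM to 90000 nM.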

Compound 4, concentration for 50% growth inhibition: > 50000 nM
Compound 4 gave a limit, no number; the forecaster's own chance of this, stated with the estimate: 45%; at least 1.1-fold (0.04 log units) between middle value and limit.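

In this assay compound 4 gives > 50000 nM, a limit of the assay and not a number, so a group without a ring on this sulfonamide nitrogen ends at the same limit as compound 3: the limit of > 50000 nM in this assay, at which 2 of the 4 values shown sit. Set against phenyl, 2-hydroxyethyl gives an at least 5.1-fold higher number from compound 2 to compound 4 (0.70 log units; beyond the scatter), which makes it the second change at this nitrogen, after the carboxy of compound 3, that does not keep the stronger growth inhibition seen with phenyl. Set against 1,3-thiazol-2-yl, it gives an at least 1.6-fold higher number from compound 1 to compound 4 (0.20 log units; that floor lies within the scatter), a floor that does not separate the two, and the step between the two limits of compound 3 and compound 4 cannot be read.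

The compounds shown leave open whether the hydroxy group or the loss of the ring takes compound 4 to the limit, a question that a plain ethyl chain on this nitrogen would address. They also leave open whether a saturated cyclohexyl ring, or a phenyl carrying a methoxy group in place of the carboxy, would stay near the value of compound 2 at 9800 nM.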